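Amide aryl exchange on a cytotoxicity series

A few compounds are considered here, and "the series" means these few. Any claim that something is new, unique, unknown or untested is made for them only; others in the source may bear on it.

Compound 1 `COc1ccc2nc(C)cc(OCC(=O)Nc3cc(C)cc(C)c3)c2c1` is one of three measured compounds; in a toxicity assay on HepG2 cells (Homo sapiens) for inhibition, read by CellTiter-Glo, with a stated time of 48 h (on this read-out lower numbers stand for stronger inhibition and higher numbers for weaker inhibition), compound 1 gives 20000 nM. Compound 2 `COc1cc2nc(C)cc(OCC(=O)Nc3cc(C)cc(C)c3)c2cc1OC` gives 10000 nM, and compound 3 `COc1ccc2nc(C)cc(OC(C)C(=O)Nc3cc(C)cc(C)c3)c2c1` gives 39800 nM. Compound 1 thus stands second highest of the three numbers, yet both a 2.0-fold lower number from compound 1 to compound 2 (0.30 log units; within the scatter) and a 2.0-fold higher number from compound 1 to compound 3 (0.30 log units; within the scatter) stay within the scatter, so no order among compounds 1, 2 and 3 can be read from these figures.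

Compound 4 `COc1ccc2nc(C)cc(OCC(=O)Nc3ccc(Cl)cc3Cl)c2c1` is not yet measured. It differs from compound 1 by 2,4-dichlorophenyl in place of 3,5-dimethylphenyl on an amide-type nitrogen. Neither measured step bears directly on this change: one adds a methoxy on an aromatic carbon of the core, the other adds a methyl on a saturated chain carbon bound to a carbonyl carbon and an oxygen on an aromatic ring, and both leave the amide nitrogen and its aryl untouched. Within the data shown here, no step anywhere exceeds the scatter, so there is no precedent for a large move. Compound 4 is expected to give 20000 nM in this assay, with a range from 7000 nM to 60000 nM. This estimate amounts to an expected no change at the digits printed from compound 1 to compound 4 (within the scatter), nothing beyond the scatter.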

Compound 4, half-maximal inhibitory concentration: > 100000 nM
Compound 4: only a limit was reported (the forecaster's own chance of this, stated with the estimate: 15%); at least 5.0-fold (0.69 log units) between middle value and limit.
By their numbers in this assay, from the lowest: compounds 2, 1 and 3 (each within the scatter of the next, the first and the last beyond it). At a limit, above all of these: compound 4.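

Among these compounds, the aryl on the amide-type nitrogen is the first place where a step leaves the scatter: there is an at least 5.0-fold higher number from compound 1 to compound 4 (0.69 log units; beyond the scatter) on exchange of 3,5-dimethylphenyl for 2,4-dichlorophenyl. In this assay compound 4 gives > 100000 nM, which is a limit of the assay and not a number. The shift is therefore toward weaker inhibition, and its full size stays unread because the value sits at the limit: the limit of > 100000 nM in this assay, at which 1 of the 4 values shown sits.

Open, as far as these compounds go, is whether the step follows from the loss of the two methyl groups, the arrival of the two chlorines, or both together. From the compounds shown here alone, a plain phenyl, a phenyl carrying a single chlorine or a cyclohexyl on the same nitrogen would separate these readings, and the effect of the exchange on the other cores remains unknown.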